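Dibromoalkene ester series: acyl sulfonamide step in kidney microsomes

The compounds below may be only part of what the source reports. "The series", "measured", "known", "first", "only" and "open" are said of these compounds alone.

Measured so far:
compound 1 `C#CC#CC(O)CCc1ccccc1-c1ccccc1CO` gives 5000 nM in an ADME assay on microsomes from kidney for inhibition of cytochrome P450 2C23 (Rattus norvegicus); on this read-out higher numbers stand for weaker inhibition and lower numbers for stronger inhibition;
compound 2 `COC(=O)CCCCCCCC=C(Br)Br` gives 6000 nM in this assay.

Compound 2 and compound 1 give numbers that cannot be separated within the usual scatter of this assay; the value for compound 2 is the one that reads nominally higher. Within the data shown here, no step between compounds differing in a single place has been measured, so nothing in the data shows how any change moves this read-out.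

Compound 3 `CS(=O)(=O)NC(=O)CCCCCCCC=C(Br)Br` differs from compound 2 by methanesulfonamido in place of methoxy on a carbonyl carbon. Among the measured compounds shown here, with no measured step of this kind, the working expectation is a change no larger than the scatter, if anything toward a higher number, so the step of a 1.3-fold higher number from compound 2 to compound 3 (0.12 log units; within the scatter) is expected to be small. Compound 3 is estimated at 8000 nM, within a range of 2500 nM to 25000 nM.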

Compound 3, half-maximal inhibitory concentration: 6000 nM
Compound 3: the middle estimate sits 1.3-fold (0.12 log units) above what was measured, and the stated range covers the measured number.
By their numbers in this assay, from the lowest: compounds 1, 2 and 3 (each within the scatter of the next).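

Among these compounds, the first single-place step shows that, in this assay, methanesulfonamido in place of methoxy on a carbonyl carbon gives no change at the digits printed from compound 2 to compound 3 (within the scatter) and does not separate the two compounds. At this place, therefore, the read-out accommodates a swap from 2 heavy atoms and 0 hydrogen-bond donors to 5 heavy atoms and 1 hydrogen-bond donor with no visible shift. Nothing available explains this flat result.

Going by these compounds, whether a carboxylic acid or a primary amide on the same carbonyl carbon would move the number away from this level remains open. So does the effect of a longer chain or of replacing the dibromoalkene end, as compound 1 differs from this pair in more than one place and offers no comparison.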